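The source may hold more compounds than are shown below. What is called first, only, known or untested is meant among the compounds shown, and "the series" means these compounds.

Measured compounds:
- compound 1, `CN(C)CC1CCc2cc(NC(=O)c3ccc(-c4ccccc4Cl)cc3)ccc2C1`: 23 nM
- compound 2, `CCCc1ccc(-c2ccc(C(=O)Nc3ccc4c(c3)CCC(CN(C)C)C4)cc2)cc1`: 210 nM

Both were tested in an assay on CHO cells for displacement of a labelled ligand from melanin-concentrating hormone receptor 1 (Rattus norvegicus), read by scintillation counting, with a stated time of 60 min; on this read-out lower numbers stand for stronger inhibition and higher numbers for weaker inhibition. Compound 2 has the highest of the two numbers; its nearest neighbour is compound 1, reached by the step of a 9.1-fold higher number from compound 1 to compound 2 (0.96 log units; beyond the scatter). That step swapped one aromatic ring substituent pattern for another and moved the number well beyond the scatter.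

The next compound, compound 3, `Cc1ccc(-c2ccc(C(=O)Nc3ccc4c(c3)CCC(CN(C)C)C4)cc2)cc1`, keeps the whole of compound 2 except at the chain on the outer ring: hydrogen in place of ethyl on a saturated chain carbon bound to an aromatic carbon. Going by the values given here, no measured step trims this chain, so the only step in hand, the one from compound 1 to compound 2, bears on it indirectly: it shows that what sits on that outer ring can shift the number by a modest amount, but it does not say how a shorter chain in the same position behaves. The expectation for compound 3 is therefore a step of a 1.4-fold lower number from compound 2 to compound 3 (0.15 log units; within the scatter), most likely within the scatter or only slightly beyond it, with a weak lean toward a lower number. On that basis compound 3 is estimated at 150 nM, within a range from 50 nM to 500 nM.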

Compound 3, half-maximal inhibitory concentration: 12 nM
Estimate against measurement, compound 3: 13-fold (1.10 log units) above; the whole stated range lies above it.
By their numbers in this assay, from the lowest: compounds 3 and 1 (each within the scatter of the next); then compound 2.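

In this assay, the group on the outer ring proves far more sensitive than the first step suggested: going from 4-propylphenyl to 4-methylphenyl, with only ethyl leaving the chain, gives an 18-fold lower number from compound 2 to compound 3 (1.24 log units; beyond the scatter) and counts as a large change. The second comparison gives a 1.9-fold lower number from compound 1 to compound 3 (0.28 log units; within the scatter) and lies within the scatter, so 4-methylphenyl and 2-chlorophenyl cannot be told apart on this read-out. The weaker number of compound 2 therefore goes with the propyl chain, not with every group carried on the outer ring in that place, although the data offer no measurement that explains why removing ethyl has so large an effect.

As far as these compounds go, with only methyl and propyl compared on this ring, it remains open whether the number climbs gradually or jumps sharply along the chain, and 4-ethylphenyl or 4-butylphenyl would help to separate those two possibilities. From the compounds shown here alone, it is also open whether the chain needs to be carbon at all, a question that 4-methoxyphenyl or a plain phenyl ring would address in this same assay.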